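The source may hold more compounds than are shown below. What is called first, only, known or untested is meant among the compounds shown, and "the series" means these compounds.

Compound 1, `COc1ccc(C(=O)N[C@H]2CCN(Cc3ccc(OCCCN(C)C)cc3)C2)cc1OC`: in an assay on HEK293 cells for binding affinity to Urotensin-2 receptor (Homo sapiens), read by radioligand binding (on this read-out lower numbers stand for stronger inhibition and higher numbers for weaker inhibition), compound 1 gives < 10000 nM, which is a limit of the assay and not a number.
Compound 2, `CN(C)CCCOc1ccc(CN2CC[C@H](NC(=O)c3ccc(C#N)cc3)C2)cc1`: in this assay compound 2 gives < 10000 nM, likewise a limit.
Compound 3, `CN(C)CCCOc1ccc(CN2CC[C@H](NC(=O)c3ccco3)C2)cc1`: in this assay compound 3 gives < 10000 nM, again a limit.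

Compound 3 therefore stands nowhere definite on the numbers shown. Its own value is a limit, and the two further values are limits as well; all three sit at the same place, (the limit of < 10000 nM in this assay, at which 3 of the 3 values shown sit). As a consequence none of the steps among the measured compounds can be read: the change from compound 1 to compound 2 gives a step that the two limits leave unreadable from compound 1 to compound 2, that from compound 1 to compound 3 gives a step that the two limits leave unreadable from compound 1 to compound 3, and that from compound 2 to compound 3 gives a step that the two limits leave unreadable from compound 2 to compound 3.

Compound 4 is `CN(C)CCCOc1ccc(CN2CC[C@H](NC(=O)c3ccncc3)C2)cc1`. It differs from compound 3 by pyridin-4-yl in place of furan-2-yl on a carbonyl carbon. The three measured steps all concern the group on the carbonyl carbon, so they are the ones that bear on this change, but each is unreadable, and no size or direction of step in this assay can be drawn from them.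

Compound 4 is expected to give 2000 nM in this assay, with a range from 300 nM to 10000 nM. The step from compound 3 to compound 4 implied by this estimate, a step that the limit leaves unreadable from compound 3 to compound 4, is an expectation only.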

Compound 4, inhibition constant: < 10000 nM
Compound 4 ended at the assay's limit; the forecaster's own chance of this, stated with the estimate: 70%; the middle value is on the limit's open side.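

Compound 4 sits at a limit of this assay, as do compound 1, compound 2 and compound 3, so none of the steps to compound 4 can be read: the limit of < 10000 nM in this assay, at which 4 of the 4 values shown sit.

The compounds shown leave open how the four compare with one another and whether the group on the carbonyl carbon matters at all in this assay.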